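This account rests on a few compounds, and the source may have more. Where it says the series, first, only, none or still open, it means among the compounds named here.

Measured compounds:
Compound 1 `O=C1/C(=C/c2ccccc2F)CN(C(=S)SCc2cn(Cc3ccccc3Cl)nn2)C/C1=C\c1ccccc1F` — in a functional assay on MCF7 cells (Homo sapiens) for cytotoxicity, read by MTT assay, with a stated time of 24 h (on this read-out higher numbers stand for weaker inhibition and lower numbers for stronger inhibition), compound 1 gives 78700 nM.
Compound 2 `O=C1/C(=C/c2ccccc2F)CN(C(=S)SCc2cn(Cc3ccc(F)cc3)nn2)C/C1=C\c1ccccc1F` — in this assay compound 2 gives 56900 nM.
Compound 3 `COc1ccc(/C=C2\CN(Cc3cn(Cc4ccc(F)cc4)nn3)C/C(=C\c3ccc(OC)cc3)C2=O)cc1` — for compound 3 this assay reports only a limit, > 100000 nM.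

Across the measured pair, the change 2-chlorophenyl in place of 4-fluorophenyl on a saturated chain carbon bound to an aromatic nitrogen produced a 1.4-fold higher number from compound 2 to compound 1 (0.14 log units; within the scatter), so it left potency essentially unchanged. How the core of compound 2 differs from the core of compound 3 is not broken down here.

Compound 4 `COc1ccc(/C=C2\CN(Cc3cn(Cc4ccccc4Cl)nn3)C/C(=C\c3ccc(OC)cc3)C2=O)cc1` carries the same change relative to compound 3, namely (2-chlorophenyl in place of 4-fluorophenyl on a saturated chain carbon bound to an aromatic nitrogen); the place is identical in wording, so this is the same change as before. Since compound 3 already sits at the limit of > 100000 nM in this assay, at which 1 of the 3 values shown sits, and the earlier step was within the scatter, the step that the limit leaves unreadable from compound 3 to compound 4 is expected to be small and likely to stay beyond the limit. Compound 4 is therefore estimated at 150000 nM, with a range from 80000 nM to 300000 nM expected.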

Compound 4, half-maximal inhibitory concentration: > 100000 nM
Compound 4 ended at the assay's limit (the forecaster's own chance of this, stated with the estimate: 80%); the middle value lies beyond the limit too.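

In this assay, going by these compounds alone, compound 4 gives > 100000 nM as a limit, so no step from compound 3, also held at a limit, can be read: the limit of > 100000 nM in this assay, at which 2 of the 4 values shown sit. Still open, from the compounds shown here alone, is how far beyond the limit compound 3 and compound 4 lie, and whether 2-chlorophenyl and 4-fluorophenyl differ on this core.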